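The source may report more compounds than this note shows. Statements on the series, on what has been measured and on what is new or still open speak of the compounds shown alone.

Series notes. Three amides on a shared core have been run in a functional assay on HT-29 cells (Homo sapiens) for cytotoxicity, read by MTT assay, with a stated time of 72 h; a lower number here means a stronger inhibitor, a higher number a weaker inhibitor. Compound 1 `O=C(Nc1nc2ccccc2s1)c1cn(-c2ccccc2)nc1-c1ccc(F)cc1` gives 9060 nM. Compound 2 `O=C(Nc1nc2ccc(Cl)cc2s1)c1cn(-c2ccccc2)nc1-c1ccc(F)cc1`, with chloro in place of hydrogen on an aromatic carbon, gives 3320 nM, the step being a 2.7-fold lower number from compound 1 to compound 2 (0.44 log units; beyond the scatter). Compound 3 `Cc1ccc2nc(NC(=O)c3cn(-c4ccccc4)nc3-c3ccc(F)cc3)sc2c1`, with methyl in place of hydrogen on an aromatic carbon, gives 22900 nM, the step of a 2.5-fold higher number from compound 1 to compound 3 (0.40 log units; beyond the scatter); between the two substituted analogues the step is a 6.9-fold higher number from compound 2 to compound 3 (0.84 log units; beyond the scatter). Compound 2 thus stands lowest of the three, and both of its steps to the others are beyond the scatter, so it is the strongest inhibitor so far.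

Compound 4 `COc1ccc(-c2nn(-c3ccccc3)cc2C(=O)Nc2nc3ccc(Cl)cc3s2)cc1` differs from compound 2 in methoxy in place of fluoro on an aromatic carbon. Among the compounds with values here, none of the measured steps touches this ring; all three concern the bicyclic end of the core, so they give no direct guide to the size or direction of this change. With nothing to point either way, the expectation is a step within the scatter, and the expected step is a 1.2-fold higher number from compound 2 to compound 4 (0.08 log units; within the scatter). The estimate for compound 4 in this assay is 4000 nM, with a range from 1500 nM to 12000 nM.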

Compound 4, half-maximal inhibitory concentration: 6570 nM
For compound 4 the middle estimate is 1.6-fold (0.22 log units) below the measured one, and the stated range covers the measured number.
By their numbers in this assay, from the lowest: compounds 2, 4 and 1 (each within the scatter of the next, the first and the last beyond it); then compound 3.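

Working from the chloro analogue, the change from 4-fluorophenyl to 4-methoxyphenyl gives a 2.0-fold higher number from compound 2 to compound 4 (0.30 log units; within the scatter) in this assay, the first reading at this position of the shared core. The step lies within the scatter, so compound 2 and compound 4 cannot be told apart here, and compound 2 no longer stands clear of every other compound in the series. On this pair, methoxy, which counts a hydrogen-bond acceptor where fluoro counts none, brings no step beyond the scatter, and nothing available explains this result.

As far as these compounds go, whether this carbon accepts other groups, such as an amine, a carboxylic acid or a longer chain like butoxy, stays open, as does the reading with plain hydrogen there. Also open, from the compounds shown here alone, is whether methoxy gives a similar step on the core of compound 1, which lacks the chloro.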